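This account rests on a few compounds, and the source may have more. Where it says the series, first, only, none or still open, it means among the compounds named here.

Compound 1 `CCCNC(=O)/N=C(\N)NCCCc1sc(N)nc1C` and compound 2 `Cc1nc(N)sc1CCCN/C(N)=N/C(=O)N[C@@H](C)c1ccccc1` share the same core and differ only in the group carried on an amide-type nitrogen. In a functional assay on HEK293T cells for agonist activity at histamine H2 receptor (Homo sapiens), read by beta-arrestin recruitment (a higher number here means a larger maximal response, a lower number a smaller maximal response), compound 1 gives 0.32, while compound 2 gives 0.46. For the measured compounds named here, of the two numbers known so far, compound 2 stands highest, and the only measured step, a number 0.14 higher from compound 1 to compound 2 (beyond the scatter), shows that the 1-phenylethyl group goes with a larger maximal response than propyl.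

Compound 3 `Cc1nc(N)sc1CCCN/C(N)=N/C(=O)Nc1ccccc1` differs from compound 2 in one place: phenyl in place of 1-phenylethyl on an amide-type nitrogen. The aromatic ring stays on that nitrogen, but the carbon that carried the methyl group and the stereocentre is gone. Going by the values given here, the one measured step bears on this only loosely, since it compares an aromatic group with a plain chain rather than two aromatic groups with each other, so the direction here cannot be read from it with confidence. With the ring kept, the expected step a number 0.060 lower from compound 2 to compound 3 (within the scatter) is small, and the number may sit anywhere within the usual scatter of compound 2. For compound 3 the estimated value in this assay is 0.4, with a likely range from 0.25 to 0.55.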

Compound 3, intrinsic activity: the largest response reached, as a fraction of the reference agonist's: 0.25
Estimate against measurement, compound 3: 0.15 above, and the stated range covers the measured number.
By their numbers in this assay, from the lowest: compounds 3 and 1 (each within the scatter of the next); then compound 2.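

In this assay, keeping the aromatic ring on the amide-type nitrogen does not keep the larger maximal response: the step is a number 0.21 lower from compound 2 to compound 3 (beyond the scatter) and the change removes only the carbon that carried the methyl group and the stereocentre. Phenyl also does not stand apart from the plain propyl chain, with a number 0.070 lower from compound 1 to compound 3 (within the scatter), so among these three compounds the higher response goes with the whole 1-phenylethyl group and not with the presence of an aromatic ring alone. Nothing available here explains the difference between phenyl and 1-phenylethyl.

The step from 1-phenylethyl to phenyl changes several things at once, so these compounds do not show whether the extra carbon, the methyl group or the defined stereocentre matters most. Benzyl, which keeps that carbon without the methyl group, the mirror-image form of 1-phenylethyl and the longer 2-phenylethyl group would each help separate these features, and it remains open how far the response follows any one of them.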